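Five fluorines on sulfur in a cytotoxicity series

This account rests on a few compounds, and the source may have more. Where it says the series, first, only, none or still open, it means among the compounds named here.

Measured in an ADME assay on Huh7.5.1 cells (Homo sapiens) for cytotoxicity, read by WST assay, with a stated time of 48 h; a higher number here means that more compound is tolerated, a lower number that less compound is tolerated:
Compound 1 `Cc1c(-c2ccc(Cc3ccc(OCC(F)(F)F)cc3)cc2)[nH]c2cccc(F)c2c1=O`: > 5000 nM
Compound 2 `Cc1c(-c2ccc(Cc3ccc([S+]([O-])C(F)(F)F)cc3)cc2)[nH]c2cccc(F)c2c1=O`: > 5000 nM
Compound 3 `Cc1c(-c2ccc(Cc3ccc(S(=N)(=O)C(F)(F)F)cc3)cc2)[nH]c2cccc(F)c2c1=O`: > 10000 nM

None of these three entries is a number, since each is a limit of the assay. The entries rest at two limits: the limit of > 5000 nM in this assay, at which 2 of the 3 values shown sit, and (the limit of > 10000 nM in this assay, at which 1 of the 3 values shown sits).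

In this assay compound 2 gives > 5000 nM, which is a limit. Its exact standing therefore cannot be read, and it cannot be ranked against the other two compounds.

The next compound, compound 4 `Cc1c(-c2ccc(Cc3ccc(S(F)(F)(F)(F)F)cc3)cc2)[nH]c2cccc(F)c2c1=O`, has not yet been measured. The change from compound 2 is a group of 6 heavy atoms (5 fluorine, 1 sulfur; no ring) in place of a group of 6 heavy atoms (1 carbon, 1 oxygen, 3 fluorine, 1 sulfur; no ring), on an aromatic carbon. It lies on an aromatic carbon of a six-membered aromatic ring of carbon only, para to a large group.

Within the data shown here, three measured steps bear on this change: a step that the two limits leave unreadable from compound 1 to compound 2, a step that the two limits leave unreadable from compound 2 to compound 3 and a step that the two limits leave unreadable from compound 1 to compound 3. None of them has a readable size, so they offer no measured effect to carry over. The expectation rests mainly on compound 2, whose limit is > 5000 nM.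

No step beyond the usual scatter is expected in either direction, and compound 4 is likely to be reported as a limit too. The expected change is a step that the limit leaves unreadable from compound 2 to compound 4. For compound 4 the estimate is 7000 nM, with an expected range from 3000 nM to 16000 nM.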

Compound 4, half-maximal cytotoxic concentration: > 5000 nM
Compound 4 was reported as a limit; the forecaster's own chance of this, stated with the estimate: 85%; the middle value does not contradict the limit.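

In this assay compound 4 gives > 5000 nM, which is a limit of the assay and not a number. Compound 1, compound 2 and compound 3 also stand at limits, and the steps from each of them to compound 4 cannot be read. The compounds shown leave open the actual half-maximal cytotoxic concentration of all four, and whether exchanging these groups changes it at all.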